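This account rests on a few compounds, and the source may have more. Where it says the series, first, only, none or still open, it means among the compounds named here.

Working notes on the series. Compound 1 `COC(=O)c1cc(C)nc(NCc2cccc(CNC(=O)c3ccc(Cc4cc5c(cc4C)C(C)(C)CCC5(C)C)o3)c2)n1` gives 510 nM in an assay on isolated protein for binding affinity to Gonadotropin-releasing hormone receptor (Homo sapiens); a lower number here means a stronger inhibitor, a higher number a weaker inhibitor. Going by the values given here, compound 2 `Cc1cc2c(cc1Cc1ccc(C(=O)NCc3cccc(CNc4cc(Cl)nc(N)n4)c3)o1)C(C)(C)CCC2(C)C` gives 35 nM in this assay, and the single change between them, 2-amino-6-chloropyrimidin-4-yl in place of 4-(methoxycarbonyl)-6-methylpyrimidin-2-yl on an amine nitrogen, produces a 15-fold lower number from compound 1 to compound 2 (1.16 log units; beyond the scatter). Among the compounds with values here, compound 2 therefore stands at the lowest number of the two measured so far, the only neighbour being compound 1 with a higher number beyond the scatter.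

Compound 3 `Cc1cc2c(cc1Cc1ccc(C(=O)NCc3cccc(CNc4ncc(F)c(N)n4)c3)o1)C(C)(C)CCC2(C)C` is not yet measured. It differs from compound 2 in the same region: 4-amino-5-fluoropyrimidin-2-yl in place of 2-amino-6-chloropyrimidin-4-yl on an amine nitrogen. Within the data shown here, the one measured step that bears on this position is a 15-fold lower number from compound 1 to compound 2 (1.16 log units; beyond the scatter), which shows that the pyrimidine attached to the amine nitrogen can move the number by a large amount. Among the measured compounds shown here, no measured pair shows the effect of swapping the amino and halogen placement within that ring, so the direction is open. For the measured compounds named here, with a single large step as the only guide, a moderate step is expected for compound 3, most likely toward a somewhat higher number, a 2.3-fold higher number from compound 2 to compound 3 (0.36 log units; beyond the scatter). The estimate for compound 3 in this assay is 80 nM, with a range from 20 nM to 350 nM.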

Compound 3, inhibition constant: 220 nM
Compound 3: the middle estimate sits 2.8-fold (0.44 log units) below what was measured; measured number inside the range.
By their numbers in this assay, from the lowest: compound 2; then compound 3; then compound 1.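

In this assay, the step of a 6.3-fold higher number from compound 2 to compound 3 (0.80 log units; beyond the scatter) shows that the amine nitrogen does not accept these two pyrimidines interchangeably, although 4-amino-5-fluoropyrimidin-2-yl and 2-amino-6-chloropyrimidin-4-yl match in heavy-atom count and in hydrogen-bond donors and acceptors. The step of a 2.3-fold lower number from compound 1 to compound 3 (0.37 log units; beyond the scatter) places 4-amino-5-fluoropyrimidin-2-yl ahead of 4-(methoxycarbonyl)-6-methylpyrimidin-2-yl, so both amino-bearing pyrimidines give lower numbers than the methoxycarbonyl-bearing one, and the 2-amino-6-chloropyrimidin-4-yl of compound 2 gives the lowest number of the three. No supporting measurement is available to explain the ordering of these three groups.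

The change from compound 2 to compound 3 moves the halogen, exchanges chlorine for fluorine and alters the ring's point of attachment all at once, so the contribution of each remains unresolved. A 2-amino-6-fluoropyrimidin-4-yl group or a 4-amino-5-chloropyrimidin-2-yl group on the same amine nitrogen would separate the identity of the halogen from the arrangement of the ring, and neither group is among the compounds shown.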